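Moving the amide one carbon out on the piperidine of compound 1

The source may hold more compounds than are shown below. What is called first, only, known or untested is meant among the compounds shown, and "the series" means these compounds.

Measured so far:
Compound 1, `CCCCNC(=O)C1CCN(c2nc(N)c3cc(OC)c(OC)cc3n2)CC1`, in an assay on isolated protein for displacement of a labelled ligand from Adrenergic receptor alpha-1 (Rattus norvegicus) (a higher number here means a weaker inhibitor, a lower number a stronger inhibitor), gives 0.67 nM.
Compound 2, `COc1cc2nc(N3CCC(C(=O)N4CCOCC4)CC3)nc(N)c2cc1OC`, in this assay gives 1.14 nM.

Compound 1 has the lowest of the two numbers in this assay; its nearest neighbour is compound 2, and the step of a 1.7-fold higher number from compound 1 to compound 2 (0.23 log units; within the scatter) lies within the scatter, so the two compounds cannot be told apart on these data.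

Compound 3, `CCCNC(=O)CC1CCN(c2nc(N)c3cc(OC)c(OC)cc3n2)CC1`, has not yet been measured. It differs from compound 1 as follows: (propylcarbamoyl)methyl in place of butylcarbamoyl on a saturated ring carbon. Within the data shown here, the only measured step, from compound 1 to compound 2, exchanges the group on the carbonyl carbon and leaves the ring carbon unchanged, so it bears on compound 3 only as a sign that the amide portion tolerates some variation without a shift beyond the scatter. Among the measured compounds shown here, with that as the sole guide, compound 3 is expected to show a step of a 1.6-fold higher number from compound 1 to compound 3 (0.22 log units; within the scatter), small and uncertain in direction. The estimate for compound 3 in this assay is 1.1 nM, within a range of 0.3 nM to 4 nM.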

Compound 3, inhibition constant: 0.65 nM
Compound 3: the middle estimate sits 1.7-fold (0.23 log units) above what was measured; the measured number falls inside the stated range.
By their numbers in this assay, from the lowest: compounds 3, 1 and 2 (each within the scatter of the next).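

In this assay, the step of a 1.0-fold lower number from compound 1 to compound 3 (0.01 log units; within the scatter) shows that the carbonyl can move one carbon further from the saturated ring carbon, as (propylcarbamoyl)methyl replaces butylcarbamoyl, without the number leaving the scatter. The earlier compounds shown here varied only the group on the carbonyl carbon, whereas this change alters the link to the ring itself, and the step of a 1.8-fold lower number from compound 2 to compound 3 (0.24 log units; within the scatter), which replaces (morpholin-4-yl)carbonyl, also stays within the scatter. No measured evidence here bears on why these changes leave the number within the scatter.

Going by these compounds, whether a longer chain between the ring carbon and the carbonyl would also stay within the scatter remains open. So does the result of replacing the amide with a carboxylic acid or an amine at this position.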